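Dropping a Sulfur From a Thromboxane Receptor Antagonist

The source may report more compounds than this note shows. Statements on the series, on what has been measured and on what is new or still open speak of the compounds shown alone.

Compound 1 `CCCCSCSCC1C2CCC(O2)C1C/C=C\CCCC(=O)O` was measured in a functional assay on a cell-free system (plasma) for inhibition of thromboxane A2 receptor (Homo sapiens) (on this read-out lower numbers stand for stronger inhibition and higher numbers for weaker inhibition), and gives 700 nM, the lowest of the two numbers at hand. Compound 2 `CCCCCCS(=O)(=O)CC1C2CCC(O2)C1C/C=C\CCCC(=O)O` gives 25000 nM in this assay, a clearly higher number; the two structures differ in more than one place, so their values show only the gap between them. Compound 3 `CCCCSCC1C2CCC(O2)C1C/C=C\CCCC(=O)O` has not yet been measured. It differs from compound 1 by propyl in place of butylsulfanyl on a saturated chain carbon bound to a sulfur, so one sulfur leaves the side chain. Among the measured compounds shown here, with no comparable step among measured compounds, the step of a 2.1-fold higher number from compound 1 to compound 3 (0.33 log units; beyond the scatter) is expected to be modest, toward a higher number. Compound 3 is thus estimated at 1500 nM, within 400 nM to 6000 nM.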

Compound 3, half-maximal inhibitory concentration: 1000 nM
Compound 3: middle estimate off by 1.5-fold (0.18 log units), on the high side, within the range that was stated.
By their numbers in this assay, from the lowest: compounds 1 and 3 (each within the scatter of the next); then compound 2.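

Replacing butylsulfanyl with propyl on a saturated chain carbon bound to a sulfur gives a 1.4-fold higher number from compound 1 to compound 3 (0.15 log units; within the scatter) in this assay. At this position, then, one sulfur can leave the side chain and the two compounds still cannot be told apart in this read-out. No measured evidence here explains this result.

Whether the sulfur that remains in compound 3 matters is still open, since no compound shown has an ether oxygen in its place. How an amine or a longer chain at this position would read is also unknown.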